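Moving the hydroxy group on the aryl ring of a thiosemicarbazone

This account rests on a few compounds, and the source may have more. Where it says the series, first, only, none or still open, it means among the compounds named here.

Compound 2 `C/C(=N/NC(=S)N(Cc1ccccc1)Cc1ccccc1)c1ccc(O)cc1` was tested in an ADME assay on Vero cells (Chlorocebus sabaeus) for cytotoxicity, read by MTT assay, with a stated time of 72 h (on this read-out higher numbers stand for lower toxicity in this test and lower numbers for higher toxicity in this test), where compound 2 gives 160000 nM. Compound 1 `C/C(=N/NC(=S)N(Cc1ccccc1)Cc1ccccc1)c1ccc(N)cc1` gives 161000 nM in this assay. Going by the values given here, the only step between them, a 1.0-fold lower number from compound 1 to compound 2 (0.00 log units; within the scatter), lies within the scatter, so compound 2 stands with the lower of two numbers but cannot be told apart from compound 1.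

Compound 3 `C/C(=N/NC(=S)N(Cc1ccccc1)Cc1ccccc1)c1ccccc1O` is the one not yet measured. It differs from compound 2 in 2-hydroxyphenyl in place of 4-hydroxyphenyl on a carbon with a double bond to nitrogen. Among the compounds with values here, no measured step concerns a change of this kind; the single step seen, from an amino group to a hydroxy group, showed no movement beyond the scatter. With nothing pointing to a shift in either direction, the expected step of a 1.1-fold lower number from compound 2 to compound 3 (0.03 log units; within the scatter) is none beyond the scatter. Compound 3 is therefore estimated at 150000 nM, within a range from 60000 nM to 400000 nM.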

Compound 3, half-maximal cytotoxic concentration: 160000 nM
Estimate against measurement, compound 3: 1.1-fold (0.03 log units) below; low and high end bracket the measured number.
By their numbers in this assay, from the lowest: compounds 2, 3 and 1 (each within the scatter of the next).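

Going by these compounds alone, with 2-hydroxyphenyl in place of 4-hydroxyphenyl on a carbon with a double bond to nitrogen, this assay gives no change at the digits printed from compound 2 to compound 3 (within the scatter), the first reading of where the hydroxy group sits on the aryl ring, and the two placements cannot be told apart. The swap of 2-hydroxyphenyl for 4-aminophenyl, which alters both the group and its place in one step, gives a 1.0-fold lower number from compound 1 to compound 3 (0.00 log units; within the scatter), so the three aryl groups shown all lie within the scatter of one another. No evidence at hand bears on this result.

The compounds shown leave open whether a carboxylic acid or a methoxy group in place of the hydroxy group would give a number beyond the scatter. They also leave open what a longer chain in place of the benzyl groups would do.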